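Swapping a hydroxy for a triazolylsulfanyl on a sugar core

The compounds below may be only part of what the source reports. "The series", "measured", "known", "first", "only" and "open" are said of these compounds alone.

Compound 1, `COc1cc(-c2cc(CO[C@@H]3O[C@H](CSc4ncn[nH]4)[C@H]4OC5(CCCC5)O[C@@H]34)on2)cc(OC)c1OC`, gives 87000 nM in a functional assay on HBL-100 cells (Homo sapiens) for antiproliferative activity, read by sulforhodamine B assay, with a stated time of 48 h; a lower number here means a stronger inhibitor of growth, a higher number a weaker inhibitor of growth.
Compound 2, `O=[N+]([O-])c1ccc(-c2nc(CO[C@@H]3O[C@H](CO)[C@H]4OC5(CCCC5)O[C@@H]34)no2)cc1`, gives 17000 nM.
Compound 3, `CC1(C)O[C@H]2[C@H](OCc3noc(-c4ccc([N+](=O)[O-])cc4)n3)O[C@H](CSc3ncn[nH]3)[C@H]2O1`, reaches only a limit of this assay, > 100000 nM.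

Compound 2 holds the lower of the two real numbers, and compound 1 lies beyond the usual scatter above it. Compound 4, `O=[N+]([O-])c1ccc(-c2nc(CO[C@@H]3O[C@H](CSc4ncn[nH]4)[C@H]4OC5(CCCC5)O[C@@H]34)no2)cc1`, arises from compound 2 by (1H-1,2,4-triazol-5-yl)sulfanyl in place of hydroxy on a saturated chain carbon bound to a saturated ring carbon. For the measured compounds named here, no measured pair differs in this one place alone, so the size of the step is unknown. Yet both compounds that already carry the entering group inhibit growth weakly: compound 1 with its number, and compound 3, which sits at the limit of > 100000 nM in this assay, at which 1 of the 3 values shown sits. The change from compound 2 to compound 4 is therefore expected to weaken growth inhibition, a 2.9-fold higher number from compound 2 to compound 4 (0.47 log units; beyond the scatter). Compound 4 is estimated at 50000 nM, between 15000 nM and 160000 nM.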

Compound 4, concentration for 50% growth inhibition: 24000 nM
For compound 4 the middle estimate is 2.1-fold (0.32 log units) above the measured one, and the stated range covers the measured number.
By their numbers in this assay, from the lowest: compounds 2 and 4 (each within the scatter of the next); then compound 1. At a limit, above all of these: compound 3.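

In this assay, putting (1H-1,2,4-triazol-5-yl)sulfanyl in place of hydroxy gives a 1.4-fold higher number from compound 2 to compound 4 (0.15 log units; within the scatter), so this saturated chain carbon accepts a much larger group that brings a ring, and growth inhibition stays level within the scatter. The weak results of compound 1 and compound 3 therefore cannot be pinned on this group alone. Nothing shown here explains why so large an exchange changes so little.

From the compounds shown here alone, whether an amine or a carboxylic acid at this place would lower the number remains open. So does the effect of a longer chain there.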